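Swapping the methyl of an ester for cyclopropyl

The compounds below may be only part of what the source reports. "The series", "measured", "known", "first", "only" and "open" are said of these compounds alone.

Measured compounds:
- compound 1, `Cc1cc(CCC#N)cc(C)c1Oc1cc(Nc2ccc(C#N)cc2)c(N)cc1C(=O)N(C)C`: 72.2%
- compound 2, `Cc1cc(CCC#N)cc(C)c1Oc1cc(Nc2ccc(C#N)cc2)c(N)cc1CNC1CC1`: 78.4%
- compound 3, `CC(=O)OCc1cc(N)c(Nc2ccc(C#N)cc2)cc1Oc1c(C)cc(CCC#N)cc1C`: 3%

In an ADME assay on liver for metabolic stability, with Liver microsome (Homo sapiens) as the target, read by LC-MS, using microsomes and NADPH, with a stated time of 30 min, tested at 1 uM (a higher number here means that more of the compound is left, a lower number that less of the compound is left), compound 3 gives 3%, the lowest of the three numbers. The gap to the others is large: a number 69.2 percentage points lower from compound 1 to compound 3 (beyond the scatter) and a number 75.4 percentage points lower from compound 2 to compound 3 (beyond the scatter). Compound 1 and compound 2 lie close to each other, a number 6.2 percentage points higher from compound 1 to compound 2 (within the scatter).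

Compound 4, `Cc1cc(CCC#N)cc(C)c1Oc1cc(Nc2ccc(C#N)cc2)c(N)cc1COC(=O)C1CC1`, keeps the ester of compound 3 and changes only its far end: cyclopropyl in place of methyl on a carbonyl carbon. For the measured compounds named here, none of the measured steps touches this part of the molecule. The two large steps into compound 3 show what happens when the whole acetoxymethyl group enters in place of dimethylcarbamoyl or when acetoxy replaces cyclopropylamino, and both point to a very low number for the acetoxymethyl compound. Compound 4 still carries an ester on that same chain carbon, so the expectation is a number near that of compound 3, with at most a small rise in this assay. The estimated step is a number 7 percentage points higher from compound 3 to compound 4 (within the scatter), a change that could still fall within the scatter. Compound 4 is therefore expected to give 10%, in the range 2% to 35%.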

Compound 4, percent of the compound remaining in the Liver microsome assay: 4.18%
Compound 4: middle estimate off by 5.8 percentage points, on the high side, within the range that was stated.
By their numbers in the Liver microsome assay, from the lowest: compounds 3 and 4 (each within the scatter of the next); then compounds 1 and 2 (each within the scatter of the next).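

In the Liver microsome assay, replacing methyl with cyclopropyl at the far end of the ester gives a number 1.2 percentage points higher from compound 3 to compound 4 (within the scatter), so this carbonyl carbon takes two more heavy atoms and a three-membered ring with no change that can be told from scatter. In the Liver microsome assay, the low number now appears with two different ester ends, and the distance to the compounds without an ester stays large: a number 74.2 percentage points lower from compound 2 to compound 4 (beyond the scatter), and a number 68 percentage points lower from compound 1 to compound 4 (beyond the scatter). In a physicochemical assay for lipophilicity, read by HPLC, measured as octanol-water partition, with a stated time of 24 h, at pH 7.4 (a higher number here means a more lipophilic compound, a lower number a more polar compound), compound 3 gives 2.84 and compound 4 gives 2.51. The swap is not without any measured effect, since compound 4 is less lipophilic than compound 3 in the physicochemical assay, yet that shift comes with no readable change in the amount of compound left: the measured partition coefficient of compound 3, 2.84, and of compound 4, 2.51, a number 0.33 log units lower (beyond the scatter)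

Whether tert-butyl or a phenyl ring on this carbonyl carbon would lift the number remains open, since the two ester ends shown are methyl and cyclopropyl. On these data alone, the read-out gives only how much compound is left, so it also remains open whether the ester itself is broken down, which would leave a primary alcohol on the chain carbon and a carboxylic acid.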